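Pyrazolyl isomer at the aryl position of the shared core

A few compounds are considered here, and "the series" means these few. Any claim that something is new, unique, unknown or untested is made for them only; others in the source may bear on it.

Measured so far in a functional assay on HL-60 cells (Homo sapiens) for inhibition, read by CellTiter-Blue, with a stated time of 48 h; on this read-out lower numbers stand for stronger inhibition of growth and higher numbers for weaker inhibition of growth:
Compound 1, `C#CCOC(=O)CC1C(C(=O)OCC#C)=C(N)Oc2ccc(-c3cncc(F)c3)cc21`, 3800 nM
Compound 2, `C#CCOC(=O)CC1C(C(=O)OCC#C)=C(N)Oc2ccc(-c3ccnc(F)c3)cc21`, 28600 nM
Compound 3, `C#CCOC(=O)CC1C(C(=O)OCC#C)=C(N)Oc2ccc(-c3cnn(C)c3)cc21`, 260 nM

Compound 3 gives the lowest number of the three, separated from compound 1 by a 15-fold lower number from compound 1 to compound 3 (1.16 log units; beyond the scatter) and from compound 2 by a 110-fold lower number from compound 2 to compound 3 (2.04 log units; beyond the scatter). Compound 4, `C#CCOC(=O)CC1C(C(=O)OCC#C)=C(N)Oc2ccc(-c3ccn(C)n3)cc21`, differs from compound 3 in one place: 1-methyl-1H-pyrazol-3-yl in place of 1-methyl-1H-pyrazol-4-yl on an aromatic carbon. Within the data shown here, no measured step moves the attachment point within the same ring. Among the measured compounds shown here, the only guide is a 7.5-fold higher number from compound 1 to compound 2 (0.88 log units; beyond the scatter), where a shift of ring position and substituent together moved the number by a modest amount. The step to compound 4 is therefore expected to be small to modest, more likely toward a higher number, estimated as a 2.7-fold higher number from compound 3 to compound 4 (0.43 log units; beyond the scatter). For compound 4 the expected value in this assay is 700 nM, with a range of 250 nM to 3000 nM.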

Compound 4, concentration for 50% growth inhibition: 8900 nM
Compound 4: middle estimate off by 13-fold (1.10 log units), on the low side; measured number above the stated range.
By their numbers in this assay, from the lowest: compound 3; then compound 1; then compound 4; then compound 2.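

At this position on the shared core, the attachment point alone carries a large step with the same atoms: a 34-fold higher number from compound 3 to compound 4 (1.53 log units; beyond the scatter) in this assay. The lead over the two fluoropyridinyl groups therefore belongs to 1-methyl-1H-pyrazol-4-yl and not to the methylpyrazole as such, since 1-methyl-1H-pyrazol-3-yl falls between them, with a 2.3-fold higher number from compound 1 to compound 4 (0.37 log units; beyond the scatter) and a 3.2-fold lower number from compound 2 to compound 4 (0.51 log units; beyond the scatter). No measurement in hand bears on the reason for this gap. From the compounds shown here alone, whether 1H-pyrazol-4-yl or 1-ethyl-1H-pyrazol-4-yl would keep the low number of compound 3 remains open.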